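The source may hold more compounds than are shown below. What is called first, only, known or untested is meant among the compounds shown, and "the series" means these compounds.

Measured so far in a functional assay on MDA-MB-436 cells (Homo sapiens) for antiproliferative activity, read by MTT assay, with a stated time of 48 h; a lower number here means a stronger inhibitor, a higher number a weaker inhibitor:
- compound 1 `C=CS(=O)(=O)N1CCN(c2ncnc3sc(-c4ccc(C#N)cc4)cc23)CC1`: 9170 nM
- compound 2 `C=CS(=O)(=O)N1CCN(c2ncnc3sc(-c4ccc(F)nc4)cc23)CC1`: 17500 nM

Compound 2, at 17500 nM, has only compound 1 as a neighbour, and the two values lie within the scatter of each other. Compound 3 `C=CS(=O)(=O)N1CCN(c2ncnc3sc(C4=CCCCC4)cc23)CC1` keeps the shared core and the rest of compound 2 but changes one group: cyclohex-1-en-1-yl in place of 6-fluoropyridin-3-yl on an aromatic carbon. In words, cyclohex-1-en-1-yl stands in place of 6-fluoropyridin-3-yl on an aromatic carbon, next to the ring sulfur.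

Going by the values given here, only one measured step bears on this change: a 1.9-fold higher number from compound 1 to compound 2 (0.28 log units; within the scatter). That step exchanged one six-membered aromatic group for another at the same place and stayed within the scatter. Among the compounds with values here, it does not test a non-aromatic ring there, and no measured compound carries one, so the evidence is indirect. In this assay, on these data alone, no step beyond the scatter is therefore expected, and the direction remains open. The expected step is a 1.2-fold lower number from compound 2 to compound 3 (0.07 log units; within the scatter). For compound 3 the estimated value is 15000 nM, with an expected range from 6000 nM to 40000 nM.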

Compound 3, half-maximal inhibitory concentration: > 50000 nM
Compound 3 ended at the assay's limit (the forecaster's own chance of this, stated with the estimate: 10%); middle value at least 3.3-fold (0.52 log units) away from the limit.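

Compound 3 sits at a limit of this assay, which is not a number: the limit of > 50000 nM in this assay, at which 1 of the 3 values shown sits.

At this position, on an aromatic carbon next to the ring sulfur, the shown series now has its first change beyond the scatter: an at least 2.8-fold higher number from compound 2 to compound 3 (0.45 log units; beyond the scatter), and likewise an at least 5.4-fold higher number from compound 1 to compound 3 (0.73 log units; beyond the scatter). Exchanging one six-membered aromatic group for another gave only a 1.9-fold higher number from compound 1 to compound 2 (0.28 log units; within the scatter), so among these three compounds the non-aromatic, carbon-only cyclohex-1-en-1-yl is the one group that separates clearly from the others, on the weaker side, and the true size of that separation remains unknown with a limit on one side.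

Cyclohex-1-en-1-yl differs from both aromatic groups in several ways at once, so the compounds shown cannot tell whether the loss of the aromatic ring or the loss of the nitrile and the fluorine accounts for the step. An unsubstituted phenyl ring would address the first question, and a non-aromatic ring carrying an amine would show whether any non-aromatic ring at this place falls to the same limit.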